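Benzyl change on compound 3: notes before measurement

This account rests on a few compounds, and the source may have more. Where it says the series, first, only, none or still open, it means among the compounds named here.

Values in a functional assay on MGC-803 cells (Homo sapiens) for inhibition, read by CCK-8 assay, with a stated time of 48 h; on this read-out lower numbers stand for stronger inhibition and higher numbers for weaker inhibition:
compound 1 `COc1ccc(CN(C(=O)CSc2nc3ccccc3o2)c2cc(OC)c(OC)c(OC)c2)cc1`: 450 nM
compound 2 `COc1ccc(CN(C(=O)CN2CCN(C(C)=O)CC2)c2cc(OC)c(OC)c(OC)c2)cc1`: 12800 nM
compound 3 `COc1cc(N(Cc2ccc(Cl)cc2)C(=O)CSC(=S)N2CCN(C(=O)OC(C)(C)C)CC2)cc(OC)c1OC`: 12900 nM

Compound 3, at 12900 nM, lies within the scatter of compound 2, and both stand far above compound 1. Compound 4 `COc1ccc(CN(C(=O)CSC(=S)N2CCN(C(=O)OC(C)(C)C)CC2)c2cc(OC)c(OC)c(OC)c2)cc1[N+](=O)[O-]` is compound 3 changed in one place: 4-methoxy-3-nitrophenyl in place of 4-chlorophenyl on a saturated chain carbon bound to an amide-type nitrogen. In words, 4-methoxy-3-nitrophenyl replaces 4-chlorophenyl on a saturated chain carbon bound to an amide-type nitrogen. For the measured compounds named here, no measured step covers this change. The only one, a 28-fold higher number from compound 1 to compound 2 (1.45 log units; beyond the scatter), lies elsewhere, on a saturated chain carbon bound to a carbonyl carbon, so it shows how far numbers can move in this series but gives no direction here. In this assay no step beyond the scatter is therefore expected. The estimated step is a 1.6-fold lower number from compound 3 to compound 4 (0.21 log units; within the scatter). Compound 4 is estimated at 8000 nM, with an expected range of 1500 nM to 25000 nM.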

Compound 4, half-maximal inhibitory concentration: 880 nM
Estimate against measurement, compound 4: 9.1-fold (0.96 log units) above; measured number outside the range, below it.
By their numbers in this assay, from the lowest: compounds 1 and 4 (each within the scatter of the next); then compounds 2 and 3 (each within the scatter of the next).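

The position on a saturated chain carbon bound to an amide-type nitrogen can move the numbers strongly in this assay: 4-methoxy-3-nitrophenyl in place of 4-chlorophenyl gives a 15-fold lower number from compound 3 to compound 4 (1.17 log units; beyond the scatter). The earlier large step lay on the other side of the amide, so a second site of large change now appears, with the rest of compound 3 held fixed. No measurement shown accounts for this step.

On these data alone, because the methoxy and nitro groups enter together, their separate shares remain open. A 3-nitrophenyl or 3-amino-4-methoxyphenyl group at this place could separate them.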